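A few compounds are considered here, and "the series" means these few. Any claim that something is new, unique, unknown or untested is made for them only; others in the source may bear on it.

Compound 2 `CCCCN(C)c1cc(C(C)(C)C)ccc1CNC(=O)C(C)c1ccc(NS(C)(=O)=O)c(F)c1` gives 1 nM in an assay on cells for antagonist activity at transient receptor potential cation channel subfamily V member 1 (Homo sapiens), read by FLIPR and calcium flux, with a stated time of 6 min; a lower number here means a stronger inhibitor, a higher number a weaker inhibitor. Going by the values given here, that is the lowest of the two numbers measured so far; the only other compound, compound 1 `CC(C(=O)NCc1ccc(C(C)(C)C)nc1SCc1ccccc1)c1ccc(NS(C)(=O)=O)c(F)c1`, gives 4 nM in this assay, a gap wider than the usual scatter of repeated measurements. Compound 3 `CC(C(=O)NCc1ccc(C(C)(C)C)cc1OCc1ccc(F)cc1)c1ccc(NS(C)(=O)=O)c(F)c1` has not yet been measured in this assay. It differs from compound 2 in one place: (4-fluorobenzyl)oxy in place of butyl(methyl)amino on an aromatic carbon. Among the compounds with values here, no measured step covers this exact change, so any expectation rests on the two measured compounds alone. In the changed part of the molecule compound 3 resembles compound 1 more closely than compound 2 does, and compound 1 gives 4 nM in this assay. A moderately higher number than compound 2 is therefore expected, with an estimated step of a 3.0-fold higher number from compound 2 to compound 3 (0.48 log units; beyond the scatter). For compound 3 the estimated value in this assay is 3 nM, with a likely range from 1 nM to 10 nM.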

Compound 3, inhibition constant: 3.8 nM
Beside the measured number, compound 3's estimate is 1.3-fold (0.10 log units) below it; measured number inside the range.
By their numbers in this assay, from the lowest: compound 2; then compounds 3 and 1 (each within the scatter of the next).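

In this assay, putting (4-fluorobenzyl)oxy in place of butyl(methyl)amino gives a 3.8-fold higher number from compound 2 to compound 3 (0.58 log units; beyond the scatter) and this modest step lies beyond the scatter. The position, on an aromatic carbon meta to a tert-butyl group, therefore accepts a group carrying its own aromatic ring and still gives a strong inhibitor, although the open-chain amine gives the lower number. No measurement here explains the step or shows which part of the exchange matters most.

The compounds shown leave open whether the step follows from the linking atom, the added ring or the fluorine. A benzyloxy group without fluorine, a butoxy group with the same kind of open chain, and a shorter dimethylamino group would help separate these three parts of the change.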